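The compounds below may be only part of what the source reports. "The series", "measured", "known", "first", "only" and "open" are said of these compounds alone.

Measured compounds:
Compound 1, `CC(NC(=O)C#Cc1ccc(NC(=O)Nc2cc(C(F)(F)F)ccc2Cl)cc1)c1ccccc1`: 23200 nM
Compound 2, `CC(NC(=O)c1cccc(-c2ccc(NC(=O)Nc3ccc(Cl)c(C(F)(F)F)c3)cc2)c1)c1ccccc1`: 6460 nM
Compound 3, `CC(NC(=O)c1ccc(-c2ccc(NC(=O)Nc3cc(C(F)(F)F)ccc3Cl)cc2)cc1)c1ccccc1`: 16800 nM

In a functional assay on KETR3 cells (Homo sapiens) for inhibition, read by MTT assay, with a stated time of 120 h (on this read-out lower numbers stand for stronger inhibition and higher numbers for weaker inhibition), compound 2 gives the lowest number of the three, and the gaps to compound 3 and to compound 1 both lie beyond the usual scatter, so compound 2 is the strongest inhibitor here. Compound 4, `CNC(=O)c1cccc(-c2ccc(NC(=O)Nc3ccc(Cl)c(C(F)(F)F)c3)cc2)c1`, keeps the core of compound 2 and changes one group: methyl in place of 1-phenylethyl on an amide-type nitrogen. Among the compounds with values here, no measured pair shows what this change does. The group that leaves is large and carries a ring; the group that enters is small. The expectation is a modest loss of inhibition, with the number for compound 4 rising somewhat beyond the scatter. The estimated step from compound 2 to compound 4 is a 2.5-fold higher number from compound 2 to compound 4 (0.39 log units; beyond the scatter). Compound 4 is estimated at 16000 nM, within a range of 5000 nM to 50000 nM.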

Compound 4, half-maximal inhibitory concentration: 39300 nM
Estimate against measurement, compound 4: 2.5-fold (0.39 log units) below; the measured number falls inside the stated range.
By their numbers in this assay, from the lowest: compound 2; then compounds 3, 1 and 4 (each within the scatter of the next, the first and the last beyond it).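

In this assay, within the data shown here, the step of a 6.1-fold higher number from compound 2 to compound 4 (0.78 log units; beyond the scatter) gives the first direct reading of this position, as no earlier pair differed in one place. Replacing 1-phenylethyl with methyl on the amide-type nitrogen weakens inhibition beyond the scatter, so the group here affects the result. Nothing available explains the size of this step. The compounds shown leave open whether the aromatic ring or the rest of 1-phenylethyl matters more. A benzyl or ethyl group on this nitrogen would help separate the two.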